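The source may hold more compounds than are shown below. What is called first, only, known or untested is meant among the compounds shown, and "the series" means these compounds.

Of the compounds shown here, three have been measured in a functional assay on WIL2-NS cells (Homo sapiens) for cytotoxicity, read by MTT assay, with a stated time of 96 h; a higher number here means that more compound is needed for the effect, a lower number that less compound is needed. Compound 1 `COc1ccc(-c2[nH]c3ccccc3c2/C=C(\C#N)S(=O)(=O)c2ccccc2)cc1` gives 400 nM. Compound 2 `COc1ccc(-c2[nH]c3ccc(OC)cc3c2/C=C(\C#N)S(=O)(=O)c2ccccc2)cc1`, which carries an extra methoxy on its core, gives 500 nM. Compound 3 `CC(=O)/C(=C/c1c(-c2ccccc2)[nH]c2ccccc12)C(=O)c1ccccc1`, whose acceptor side differs from the other two, gives 12000 nM. Compound 2 thus stands between the two: its number lies within the scatter of compound 1, while the number of compound 3 is far from it, beyond the scatter.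

Compound 4 `COc1ccc2[nH]c(-c3ccccc3)c(/C=C(\C#N)S(=O)(=O)c3ccccc3)c2c1` is compound 2 with one change: hydrogen in place of methoxy on an aromatic carbon. Going by the values given here, no measured step probes exactly this change. Among the compounds with values here, the one single-point step available, a 1.3-fold higher number from compound 1 to compound 2 (0.10 log units; within the scatter), concerns a methoxy on a different ring and stayed within the scatter. Compound 3 also bears a plain phenyl, but its other changes mean its value says little about this step alone. The expectation for compound 4 in this assay is therefore a step of a 1.2-fold higher number from compound 2 to compound 4 (0.08 log units; within the scatter), nothing beyond the scatter, estimated at 600 nM with a range from 250 nM to 1500 nM.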

Compound 4, half-maximal effective concentration: 2800 nM
Beside the measured number, compound 4's estimate is 4.7-fold (0.67 log units) below it; measured number outside the range, above it.
By their numbers in this assay, from the lowest: compounds 1 and 2 (each within the scatter of the next); then compound 4; then compound 3.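

Going from 4-methoxyphenyl to phenyl gives, in this assay, a 5.6-fold higher number from compound 2 to compound 4 (0.75 log units; beyond the scatter), so less compound is needed when the methoxy is present at this place. The methoxy examined earlier gave a different picture, a 1.3-fold higher number from compound 1 to compound 2 (0.10 log units; within the scatter), so among these compounds the two methoxy places do not count alike. The data at hand give no reason why losing this methoxy matters.

The compounds shown leave open whether this position needs the methoxy itself or would accept another group, such as a hydroxyl, a methyl, a fluorine or a longer ethoxy. They also leave open whether an amine at this place would bring the number back down, and whether this methoxy would matter in the same way with the acceptor side of compound 3.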